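Swapping Hydroxy for Methyl on a Retinoid Core

A few compounds are considered here, and "the series" means these few. Any claim that something is new, unique, unknown or untested is made for them only; others in the source may bear on it.

Compound 1 `CC1(C)CCC(C)(C)c2cc(C(=O)c3ccc4cc(C(=O)O)ccc4c3O)ccc21` gives 0%
Compound 2 `CC1(C)CCC(C)(C)c2c1ccc(C(O)c1ccc3cc(C(=O)O)ccc3c1)c2F` gives 74%
Compound 3 `CC1(C)CCC(C)(C)c2cc(C(O)c3ccc4cc(C(=O)O)ccc4c3)c(O)cc21` gives 18%

In an assay on isolated protein with retinoic acid receptor beta (Homo sapiens) as the target (on this read-out lower numbers stand for smaller maximal responses and higher numbers for larger maximal responses), compound 3 stands second highest of the three numbers. Its nearest neighbour is compound 1, lower by a gap beyond the scatter; the furthest is compound 2, higher by a gap beyond the scatter. Compound 4 `Cc1cc2c(cc1C(O)c1ccc3cc(C(=O)O)ccc3c1)C(C)(C)CCC2(C)C` differs from compound 3 by methyl in place of hydroxy on an aromatic carbon. For the measured compounds named here, no pair of measured compounds differing in a single place is available, so the size of this step must be judged from the set as a whole. Compound 2, whose core carries no hydroxy, gives 74% in this assay, so an upward step beyond the scatter is expected. Compound 4 is estimated to reach 55%, within a range of 25% to 85%. For compound 4 this means an expected step of a number 37 percentage points higher from compound 3 to compound 4 (beyond the scatter).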

Compound 4, largest response reached (reported as maximum), in percent of the reference or control that the assay uses: 96%
Estimate against measurement, compound 4: 41 percentage points below, and the stated range ends below it.
By their numbers in this assay, from the lowest: compound 1; then compound 3; then compound 2; then compound 4.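

In this assay, methyl in place of hydroxy on this aromatic carbon, ortho to a large group, gives a number 78 percentage points higher from compound 3 to compound 4 (beyond the scatter). For the compounds shown here, this is the first exchange in the set that can be read at a single place, and it shows that the maximal response depends strongly on which of these two groups the position carries. Nothing available explains the size of this step.

Going by these compounds, what an amine, a methoxy group or a chlorine atom would give on this aromatic carbon remains open. On these data alone, it is also open whether the step follows from the loss of hydroxy or from the arrival of methyl.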